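A few compounds are considered here, and "the series" means these few. Any claim that something is new, unique, unknown or untested is made for them only; others in the source may bear on it.

Measured in a functional assay on A549 cells (Homo sapiens) for inhibition, read by CCK-8 assay, with a stated time of 72 h, tested at 1 uM; a higher number here means more inhibition of growth at the concentration tested, a lower number less inhibition of growth:
Compound 1 `CN(C)C(=O)c1cc2cnc(Nc3ccc(NC(=O)C4(C(=O)Nc5ccc(Cl)cc5)CC4)cc3)nc2n1C1CCCC1` gives 24.7%
Compound 2 `CN(C)C(=O)c1cc2cnc(Nc3ccc(NC(=O)C4(C(=O)Nc5ccccc5F)CC4)cc3)nc2n1C1CCCC1` gives 79.1%
Compound 3 `CN(C)C(=O)c1cc2cnc(Nc3ccc(NC(=O)C4(C(=O)Nc5ccc(Br)cc5)CC4)cc3)nc2n1C1CCCC1` gives -6.6%

Compound 3 stands lowest of the three, and its gaps to both of the others lie beyond the scatter. Compound 4 `CN(C)C(=O)c1cc2cnc(Nc3ccc(NC(=O)C4(C(=O)Nc5cccc(C#N)c5)CC4)cc3)nc2n1C1CCCC1` keeps the shared core and differs from compound 3 in one place (3-cyanophenyl in place of 4-bromophenyl on an amide-type nitrogen), with 3-cyanophenyl in place of 4-bromophenyl on an amide-type nitrogen.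

The steps of a number 31.3 percentage points lower from compound 1 to compound 3 (beyond the scatter) and a number 85.7 percentage points lower from compound 2 to compound 3 (beyond the scatter) and also a number 54.4 percentage points higher from compound 1 to compound 2 (beyond the scatter) all concern the group on that nitrogen, and all are large, so a swap here can move the number far. For the measured compounds named here, no measured compound carries the 3-cyanophenyl group, so the direction remains uncertain. With compound 3 at -6.6% there is more room to rise than to fall, so a large upward step is expected. The estimated step is a number 46.6 percentage points higher from compound 3 to compound 4 (beyond the scatter) with wide uncertainty. The expected value for compound 4 is 40% (range 0% to 80%).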

Compound 4, percent growth inhibition at one concentration: 70.8%
Compound 4: middle estimate off by 30.8 percentage points, on the low side, and the stated range covers the measured number.
By their numbers in this assay, from the lowest: compound 3; then compound 1; then compounds 4 and 2 (each within the scatter of the next).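

In this assay the 3-cyanophenyl group gives a number 77.4 percentage points higher from compound 3 to compound 4 (beyond the scatter) and a number 46.1 percentage points higher from compound 1 to compound 4 (beyond the scatter), so a high number at this amide-type nitrogen is not tied to the 2-fluorophenyl group alone. The change from that group gives a number 8.3 percentage points lower from compound 2 to compound 4 (within the scatter) and leaves these two compounds level, while the 4-chlorophenyl and 4-bromophenyl compounds both stay clearly lower, and no compound shown goes against this split. Nothing measured here explains why these groups end up so far apart.

For the compounds shown here, no two of the compounds carry the same group in different places on the ring, so the effect of the nitrile cannot be separated from the effect of where it sits. As far as these compounds go, how a phenyl ring carrying an amine or a carboxylic acid would behave on this nitrogen also stays open.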